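Aryl amide series: lipophilicity notes, compound 3 to compound 4

The compounds below may be only part of what the source reports. "The series", "measured", "known", "first", "only" and "open" are said of these compounds alone.

Three compounds of the shared core have numbers in a physicochemical assay for lipophilicity, read by HPLC, in phosphate buffer, measured as chromatographic lipophilicity, at pH 7.4; a lower number here means a more polar compound, a higher number a more lipophilic compound. Compound 1 `Cc1cc(C)cc(NC(=O)COc2cc(C)nc3ccccc23)c1` gives 5.39, compound 2 `COc1ccc2c(OCC(=O)Nc3cc(C)cc(C)c3)cc(C)nc2c1` gives 5.59, and compound 3 `COc1ccc2nc(C)cc(OCC(=O)Nc3cc(C)ccc3OC)c2c1` gives 5.65. Compound 3 has the highest of the three numbers, yet all three lie within the scatter of one another. Among the measured compounds shown here, the only measured step, a number 0.20 log units higher from compound 1 to compound 2 (within the scatter), concerns methoxy in place of hydrogen on an aromatic carbon and does not touch the amide-side ring.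

Compound 4 `COc1ccc2nc(C)cc(OCC(=O)Nc3cc(C)nc(C)n3)c2c1` differs from compound 3 by 2,6-dimethylpyrimidin-4-yl in place of 2-methoxy-5-methylphenyl on an amide-type nitrogen. For the measured compounds named here, no measured step covers this exchange, so the expectation rests on the ring change alone. Compound 4 is expected to fall in this assay by a number 1.25 log units lower from compound 3 to compound 4 (beyond the scatter). The estimate for compound 4 is 4.4, between 3.7 and 5.1.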

Compound 4, distribution coefficient: 3.24
Beside the measured number, compound 4's estimate is 1.16 log units above it; measured number outside the range, below it.
By their numbers in this assay, from the lowest: compound 4; then compounds 1, 2 and 3 (each within the scatter of the next).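

In this assay, 2,6-dimethylpyrimidin-4-yl in place of 2-methoxy-5-methylphenyl on the amide-type nitrogen gives a number 2.41 log units lower from compound 3 to compound 4 (beyond the scatter) and is the first step shown that lies beyond the scatter. This place on the amide-type nitrogen can therefore shift the number strongly, and compound 4 stands apart from the other three compounds. Nothing shown accounts for the size of this step.

Going by these compounds, whether the step belongs to the ring nitrogens or partly to the departing methoxy stays open. So does where a pyridinyl ring with a single ring nitrogen, or a phenyl ring carrying a carboxylic acid, would fall at this place.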